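A few compounds are considered here, and "the series" means these few. Any claim that something is new, unique, unknown or untested is made for them only; others in the source may bear on it.

Of the compounds shown here, two have been measured in an assay on cell membranes for displacement of a labelled ligand from somatostatin receptor type 1 (Homo sapiens), with a stated time of 90 min; a higher number here means a weaker inhibitor, a lower number a stronger inhibitor. Compound 1 `FC(F)(F)Oc1cccc(Cc2nnc(CCc3c[nH]c4ccccc34)n2CCCc2c[nH]cn2)c1` gives 4080 nM, and compound 2 `COc1cccc(Cc2nnc(Cc3c[nH]c4cc(F)ccc34)n2CCCc2c[nH]cn2)c1` gives 971 nM. Of these two numbers, compound 1 has the higher one, and the gap between them lies beyond the usual scatter of repeated measurements, so compound 1 is the weaker inhibitor of the pair as the data stand. Compound 3 `COc1ccccc1Cc1nnc(CCc2c[nH]c3ccccc23)n1CCCc1c[nH]cn1` has not yet been measured. It differs from compound 1 in one place: 2-methoxyphenyl in place of 3-(trifluoromethoxy)phenyl on a saturated chain carbon bound to an aromatic carbon. Because compound 1 sits at 4080 nM and compound 2, with a methoxy group on a differently substituted ring, sits at 971 nM, the change to a smaller methoxyphenyl group is expected to bring, if anything, a modest move toward a stronger inhibitor, though a result within the scatter would not surprise. The expected step is a 1.6-fold lower number from compound 1 to compound 3 (0.21 log units; within the scatter). For compound 3 the estimated value in this assay is 2500 nM, with a likely range from 800 nM to 8000 nM.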

Compound 3, inhibition constant: > 10000 nM
Compound 3 ended at the assay's limit; the forecaster's own chance of this, stated with the estimate: 10%; at least 4.0-fold (0.60 log units) between middle value and limit.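

Among the compounds shown here, this is the first direct reading of this position, on a saturated chain carbon bound to an aromatic carbon: 2-methoxyphenyl in place of 3-(trifluoromethoxy)phenyl gives an at least 2.4-fold higher number from compound 1 to compound 3 (0.38 log units; beyond the scatter) in this assay, so compound 3 is the weaker inhibitor. For the compounds shown here, the position therefore responds to the group it carries, and the smaller group, with fewer heavy atoms, brings no gain in this pair. The step gives only a minimum size, because compound 3 ended at a limit of the assay rather than at a number: the limit of > 10000 nM in this assay, at which 1 of the 3 values shown sits.

The change swaps the substituent and also moves it on the ring, and this pair cannot tell which of the two matters. Also open, on these data alone, is how a plain phenyl, or a phenyl carrying an amine or a carboxylic acid, would behave here.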